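The source may hold more compounds than are shown below. What is called first, only, known or untested is meant among the compounds shown, and "the series" means these compounds.

The three measured compounds share one core and differ in two places. In a functional assay on A549 cells (Homo sapiens), read by MTT assay, with a stated time of 72 h (on this read-out lower numbers stand for stronger inhibition and higher numbers for weaker inhibition), compound 2 `COc1ncnc2c1c(-c1cccs1)cn2[C@@H]1O[C@H](CO)[C@@H](O)[C@H]1O` gives 4850 nM. Compound 3 `COc1nc(N)nc2c1c(-c1cccs1)cn2[C@@H]1O[C@H](CO)[C@@H](O)[C@H]1O` reaches only the limit of this assay, > 20000 nM. Compound 1 `COc1nc(N)nc2c1c(-c1ccccc1)cn2[C@@H]1O[C@H](CO)[C@@H](O)[C@H]1O` also reaches only the limit of this assay, > 20000 nM. The difference between the cores of compound 3 and compound 2 is hydrogen in place of amino on an aromatic carbon; run the other way, it gives an at least 4.1-fold higher number from compound 2 to compound 3 (0.61 log units; beyond the scatter). The change from compound 3 to compound 1 is phenyl in place of thiophen-2-yl on an aromatic carbon, and its step is a step that the two limits leave unreadable from compound 3 to compound 1, as both values sit at the limit of > 20000 nM in this assay, at which 2 of the 3 values shown sit. Compound 4 `COc1ncnc2c1c(-c1ccccc1)cn2[C@@H]1O[C@H](CO)[C@@H](O)[C@H]1O` carries the same change from compound 2, (phenyl in place of thiophen-2-yl on an aromatic carbon). Because a step that the two limits leave unreadable from compound 3 to compound 1 offers no readable size, compound 4 is expected to stay close to compound 2, with an estimated step of a 1.4-fold higher number from compound 2 to compound 4 (0.16 log units; within the scatter). Compound 4 is therefore estimated at 7000 nM, expected between 2000 nM and 25000 nM.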

Compound 4, half-maximal inhibitory concentration: > 20000 nM
Compound 4 was reported as a limit; the forecaster's own chance of this, stated with the estimate: 25%; middle value at least 2.8-fold (0.45 log units) away from the limit.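

In this assay, phenyl in place of thiophen-2-yl gives an at least 4.1-fold higher number from compound 2 to compound 4 (0.61 log units; beyond the scatter), so on the core without the amino group the change weakens inhibition beyond the scatter. The same change on the core with the amino group, and the amino change between the two phenyl compounds, cannot be read, since each of these pairs has both values at a limit of the assay: the limit of > 20000 nM in this assay, at which 3 of the 4 values shown sit. The result therefore shows the change on one core only; it does not show that the step carries over to the other core, nor its full size.

As far as these compounds go, what a furan-2-yl or pyridin-3-yl ring would give at this place stays open. So does the effect of a small chain such as methyl or an amine there.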